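From Nitrophenyl to Fluorophenyl: A Step Upward Expected

The compounds below may be only part of what the source reports. "The series", "measured", "known", "first", "only" and "open" are said of these compounds alone.

Measured so far in a functional assay on CCRF-CEM cells (Homo sapiens) for antiproliferative activity; on this read-out lower numbers stand for stronger inhibition and higher numbers for weaker inhibition
Compound 1 `COc1cc(C(=O)c2sc(-c3ccc(-c4ccccc4)cc3)cc2N)cc(OC)c1OC` gives > 10000 nM as a limit of the assay
Compound 2 `COc1cc(C(=O)c2sc(-c3ccc([N+](=O)[O-])cc3)cc2N)cc(OC)c1OC` gives 99 nM
Compound 3 `COc1cc(C(=O)c2sc(-c3cccc([N+](=O)[O-])c3)cc2N)cc(OC)c1OC` gives 5.9 nM

Compound 3 holds the lower of the two true numbers, and its gap to compound 2 lies beyond the scatter. The next candidate is compound 4 `COc1cc(C(=O)c2sc(-c3ccc(F)cc3)cc2N)cc(OC)c1OC`, not yet measured. It has 4-fluorophenyl in place of 3-nitrophenyl on an aromatic carbon next to the ring sulfur.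

Among the measured compounds shown here, two measured steps bear on this change. The first is an at least 100-fold lower number from compound 1 to compound 2 (2.00 log units; beyond the scatter) and counts as large. The number for compound 1 in that step is a limit (the limit of > 10000 nM in this assay, at which 1 of the 3 values shown sits). The second is a 17-fold lower number from compound 2 to compound 3 (1.22 log units; beyond the scatter) and is also large, so swapping 4-nitrophenyl for 3-nitrophenyl matters here. Compound 4 again carries a 4-substituted phenyl, as compound 2 does at 99 nM and so leaves the low number of compound 3 behind. In this assay the expected change is a 6.8-fold higher number from compound 3 to compound 4 (0.83 log units; beyond the scatter) and it would mean weaker inhibition. For compound 4 the estimated value is 40 nM with an expected range from 8 nM to 300 nM in this test.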

Compound 4, half-maximal inhibitory concentration: 15 nM
Estimate against measurement, compound 4: 2.7-fold (0.43 log units) above; the measured number falls inside the stated range.
By their numbers in this assay, from the lowest: compound 3; then compound 4; then compound 2. At a limit, above all of these: compound 1.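

In this assay, swapping nitro for fluoro on the phenyl ring gives a 6.6-fold lower number from compound 2 to compound 4 (0.82 log units; beyond the scatter), so the result for 4-nitrophenyl did not speak for every substituted phenyl at this position next to the ring sulfur. Compound 3 keeps the lowest number, but the gap is now smaller, at a 2.5-fold higher number from compound 3 to compound 4 (0.41 log units; beyond the scatter), which shows that a low number here does not depend on a nitro group. Fluoro in place of phenyl gives an at least 660-fold lower number from compound 1 to compound 4 (2.82 log units; beyond the scatter), and that step rests on the number for compound 1, which is a limit: the limit of > 10000 nM in this assay, at which 1 of the 4 values shown sits.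

The compounds shown leave open whether the gain from moving nitro to the 3-position carries over to fluoro, which 3-fluorophenyl would test. They also leave open whether an amine or a carboxylic acid on the phenyl ring would keep the number low.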